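A few compounds are considered here, and "the series" means these few. Any claim that something is new, unique, unknown or untested is made for them only; others in the source may bear on it.

Measured in an assay on isolated protein for binding affinity to sphingosine 1-phosphate receptor 2 (Homo sapiens), read by surface plasmon resonance; a lower number here means tighter binding, a higher number weaker binding:

- compound 1, `Cn1nc(C(F)(F)F)c2c(-c3ccccc3)cc(NNC(=O)Nc3cc(Cl)nc(Cl)c3)nc21`: 940 nM
- compound 2, `CC(C)c1cc(NNC(=O)Nc2cc(Cl)nc(Cl)c2)nc2c1c(C(F)(F)F)nn2C`: 1250 nM
- compound 3, `CC(C)c1cc(NNC(=O)Nc2cc(Cl)nc(Cl)c2)nc2c1cnn2C`: 780 nM

Compound 2 carries the highest of the three numbers in this assay, but it is not separated from either neighbour: a 1.3-fold higher number from compound 1 to compound 2 (0.12 log units; within the scatter), and a 1.6-fold lower number from compound 2 to compound 3 (0.20 log units; within the scatter). All three compounds therefore sit in one band, and nothing among them reaches beyond the scatter.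

Compound 4, `CCCc1cc(NNC(=O)Nc2cc(Cl)nc(Cl)c2)nc2c1c(C(F)(F)F)nn2C`, is not yet measured. It differs from compound 2 by a single change: propyl in place of isopropyl on an aromatic carbon. The two compounds have the same atoms, joined differently; only the branching of the three-carbon chain changes.

Neither measured step probes this kind of change directly. The step from compound 1 to compound 2 replaces phenyl with isopropyl at the same aromatic carbon, and the step from compound 2 to compound 3 touches a different position; both stay within the scatter. With a far larger swap at this carbon leaving the number essentially unchanged, no step beyond the scatter is expected from compound 2 to compound 4 in this assay, so a 1.0-fold lower number from compound 2 to compound 4 (0.02 log units; within the scatter) is the expectation. Compound 4 is accordingly estimated at 1200 nM, with a range from 500 nM to 3000 nM.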

Compound 4, dissociation constant: 890 nM
Estimate against measurement, compound 4: 1.3-fold (0.13 log units) above; measured number inside the range.
By their numbers in this assay, from the lowest: compounds 3, 4, 1 and 2 (each within the scatter of the next).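

In this assay, the branching of the three-carbon chain on this aromatic carbon, opposite the ring nitrogen, now has a direct test: a 1.4-fold lower number from compound 2 to compound 4 (0.15 log units; within the scatter) and so does not separate propyl from isopropyl. Propyl and phenyl at the same carbon are not separated either, with a 1.1-fold lower number from compound 1 to compound 4 (0.02 log units; within the scatter) as the reading, so with trifluoromethyl held in place on the core, a branched chain, an unbranched chain and a ring all fall in one band at this carbon. No supporting measurement bears on why these groups read alike.

No group shown at this carbon yet gives a step beyond the scatter, so the limits of this flat reading remain undefined. Open, as far as these compounds go, are a longer chain such as hexyl, an amine or a carboxylic acid at this carbon, and whether propyl still reads like isopropyl when hydrogen stands in place of trifluoromethyl on the shared core.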